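Does a pyridine side chain change cell inhibition?

This account rests on a few compounds, and the source may have more. Where it says the series, first, only, none or still open, it means among the compounds named here.

Measured so far in a functional assay on RKO cells (Homo sapiens) for inhibition, read by CCK-8 assay, with a stated time of 4 days; on this read-out higher numbers stand for weaker inhibition and lower numbers for stronger inhibition
- Compound 1 `COc1cc(C(=O)O)ccc1NC(=O)[C@@H]1N[C@@H](CC(C)(C)C)[C@](CNCc2ccc(O)cc2)(c2ccc(Cl)cc2F)[C@H]1c1cccc(Cl)c1F` gives 600 nM
- Compound 2 `COc1cc(C(=O)O)ccc1NC(=O)[C@@H]1N[C@@H](CC(C)(C)C)[C@](C)(c2ccc(Cl)cc2F)[C@H]1c1cccc(Cl)c1F` gives 500 nM

Compound 2 stands at 500 nM, within the usual scatter of compound 1 at 600 nM. Compound 3 `COc1cc(C(=O)O)ccc1NC(=O)[C@@H]1N[C@@H](CC(C)(C)C)[C@](CNCc2ccccn2)(c2ccc(Cl)cc2F)[C@H]1c1cccc(Cl)c1F` is not yet measured, and it differs from compound 2 at one place: ((pyridin-2-yl)methyl)amino in place of hydrogen on a saturated chain carbon bound to a saturated ring carbon. In words, this puts ((pyridin-2-yl)methyl)amino in place of hydrogen on a saturated chain carbon bound to a saturated ring carbon.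

Among the measured compounds shown here, one measured step bears on this place, where (4-hydroxybenzyl)amino gives way to hydrogen: a 1.2-fold lower number from compound 1 to compound 2 (0.08 log units; within the scatter). That step stays within the scatter, but it is a single step, and it does not test the pyridine ring. In this assay, no step beyond the scatter is therefore expected. The estimated change is a 1.2-fold higher number from compound 2 to compound 3 (0.06 log units; within the scatter). For compound 3 the expected value is 580 nM, with an estimated range from 230 nM to 1400 nM.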

Compound 3, half-maximal inhibitory concentration: 720 nM
Compound 3: the middle estimate sits 1.2-fold (0.09 log units) below what was measured; low and high end bracket the measured number.
By their numbers in this assay, from the lowest: compounds 2, 1 and 3 (each within the scatter of the next).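

In this assay, among the compounds shown here, this is the first look at a pyridine ring at this place, and adding ((pyridin-2-yl)methyl)amino gives a 1.4-fold higher number from compound 2 to compound 3 (0.16 log units; within the scatter). Exchanging the 4-hydroxyphenyl of compound 1 for pyridin-2-yl gives a 1.2-fold higher number from compound 1 to compound 3 (0.08 log units; within the scatter), so on these numbers the two ring-bearing side chains cannot be told apart from each other or from the plain methyl of compound 2. Nothing available explains this flat result.

Going by these compounds, whether a simple amine with no aromatic ring, or a carboxylic acid, on this saturated chain carbon would move the number beyond the scatter remains open. So does the effect of shifting the ring nitrogen, as in pyridin-3-yl or pyridin-4-yl.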